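Working notes: cytotoxicity of compounds 2 and 3

This account rests on a few compounds, and the source may have more. Where it says the series, first, only, none or still open, it means among the compounds named here.

compound 1 `CCCCOc1ccc(S(=O)(=O)Nc2ccc3nc(NC(=O)C4CCCCC4)sc3c2)cc1`: 0.75 ug/mL
compound 2 `O=C(O)CCC(=O)Nc1nc2ccc(NC(=O)c3c(Cl)cccc3Cl)cc2s1`: > 6.6 ug/mL

In a functional assay on WI-38 VA13 cells (Homo sapiens) for cytotoxicity (on this read-out lower numbers stand for an effect already at smaller amounts and higher numbers for an effect only at larger amounts of compound), compound 1 gives 0.75 ug/mL. For compound 2 the assay reports only a limit, > 6.6 ug/mL, so compound 2 sits at the limit of > 6.6 ug/mL in this assay, at which 1 of the 2 values shown sits. Within the data shown here, no step between measured compounds is available here. Compound 3 `CC(C)NC(=O)Nc1nc2ccc(NC(=O)c3c(Cl)cccc3Cl)cc2s1` differs from compound 2 in one place: isopropylamino in place of 2-carboxyethyl on a carbonyl carbon. The step expected is an at least 1.3-fold lower number from compound 2 to compound 3 (0.12 log units; that floor lies within the scatter), a modest move toward an effect at smaller amounts, with a repeat of the limit still well possible. Compound 3 is expected in this assay at 5 ug/mL, within 1.5 ug/mL to 15 ug/mL.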

Compound 3, half-maximal effective concentration: 0.03 ug/mL
Compound 3: middle estimate off by 170-fold (2.22 log units), on the high side, outside the stated range (below it).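

On a carbonyl carbon whose other neighbour is an amide-type nitrogen, isopropylamino in place of 2-carboxyethyl gives an at least 220-fold lower number from compound 2 to compound 3 (2.34 log units; beyond the scatter) in this assay. Among these compounds, this is the first pair to differ in one place, and it shows that this single change can move the read-out strongly. Compound 2 stands at a limit, so the step is only a floor: the limit of > 6.6 ug/mL in this assay, at which 1 of the 3 values shown sits.

Open, from the compounds shown here alone, is whether the step goes with the loss of the carboxylic acid or with the entry of the nitrogen. An isopropyl or a methylamino group on that carbonyl carbon would help separate the two.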